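Swapping Oxygen for Sulfur on a Dichlorophenyl Linker

The compounds below may be only part of what the source reports. "The series", "measured", "known", "first", "only" and "open" are said of these compounds alone.

Compound 1 `Nc1cc(N)c2nc(-c3ccccc3)c(Oc3ccc(Cl)c(Cl)c3)nc2c1` was tested in a functional assay on HCT-116 cells (Homo sapiens) for inhibition, read by sulforhodamine B assay, with a stated time of 48 h; a lower number here means that less compound is tolerated, a higher number that more compound is tolerated. There compound 1 gives < 100000 nM, which is a limit of the assay rather than a measured number. Compound 2 `CCOC(=O)[C@H](CCC(=O)O)NC(=O)c1ccc(CNc2nc3cc(N)cc(N)c3nc2-c2ccccc2)cc1`, a larger relative built on the same core, was tested in this assay as well. There compound 2 gives < 100000 nM, again a limit and not a number. On these figures compound 1 cannot be placed ahead of or behind compound 2, and the limit of < 100000 nM in this assay, at which 2 of the 2 values shown sit, describes everything shown so far.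

Compound 3 `Nc1cc(N)c2nc(-c3ccccc3)c(Sc3ccc(Cl)c(Cl)c3)nc2c1` has not yet been measured. It differs from compound 1 in a single place: (3,4-dichlorophenyl)sulfanyl in place of 3,4-dichlorophenoxy on an aromatic carbon. Going by the values given here, no step between two measured compounds is available to size this change, so the expectation rests on the limits alone. The step from compound 1 to compound 3 in this assay is expected to be a step that the limit leaves unreadable from compound 1 to compound 3, nothing beyond the usual scatter in either direction. Compound 3 is therefore estimated at 30000 nM, within a range from 5000 nM to 100000 nM, and it may well be reported as a limit once more.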

Compound 3, concentration lethal to 50% of the cells: < 100000 nM
Compound 3: a limit, no number; the forecaster's own chance of this, stated with the estimate: 60%; the middle value lies beyond the limit too.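

In this assay compound 3 gives < 100000 nM, which is a limit of the assay and not a number. No step can be read between compound 1 and compound 3 because both results are limits: the limit of < 100000 nM in this assay, at which 3 of the 3 values shown sit.

The compounds shown leave open whether (3,4-dichlorophenyl)sulfanyl in place of 3,4-dichlorophenoxy changes the lethal concentration at all, and in which direction.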